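Replacing a phenol hydrogen with 4-bromobenzyl

A few compounds are considered here, and "the series" means these few. Any claim that something is new, unique, unknown or untested is made for them only; others in the source may bear on it.

Measured so far in a functional assay on RAW264.7 cells (Mus musculus) for inhibition, read by Griess assay, with stated times of 1 h and 24 h; on this read-out higher numbers stand for weaker inhibition and lower numbers for stronger inhibition:
compound 1, `COc1cc(OC)c2c(c1)C(C(O)c1ccc(O)cc1)OC2=O`, gives > 10000 nM, which is a limit of the assay, not a number.
compound 2, `CCCOc1ccc(C(O)C2OC(=O)c3c(OC)cc(OC)cc32)cc1`, gives 9260 nM.
compound 3, `COCCCOc1ccc(C(O)C2OC(=O)c3c(OC)cc(OC)cc32)cc1`, gives 1260 nM.

Compound 1 therefore has no measured number, only (the limit of > 10000 nM in this assay, at which 1 of the 3 values shown sits). Compound 4, `COc1cc(OC)c2c(c1)C(C(O)c1ccc(OCc3ccc(Br)cc3)cc1)OC2=O`, differs from it by 4-bromobenzyl in place of hydrogen on an oxygen on an aromatic ring. Two measured steps start from the same oxygen: an at least 1.0-fold lower number from compound 1 to compound 2 (0.03 log units; that floor lies within the scatter) and an at least 7.9-fold lower number from compound 1 to compound 3 (0.89 log units; beyond the scatter). So adding a chain to this oxygen gave anything from no change beyond the scatter to a modest gain. A 4-bromobenzyl group is a further, different addition at the same place, and a drop of similar size is expected, with wide uncertainty; the estimated step is an at least 3.3-fold lower number from compound 1 to compound 4 (0.52 log units; beyond the scatter). For compound 4 the expected value is 3000 nM, in the range 700 nM to 12000 nM.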

Compound 4, half-maximal inhibitory concentration: 6530 nM
Beside the measured number, compound 4's estimate is 2.2-fold (0.34 log units) below it, within the range that was stated.
By their numbers in this assay, from the lowest: compound 3; then compounds 4 and 2 (each within the scatter of the next). At a limit, above all of these: compound 1.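

Putting a ring on this oxygen changes little compared with a plain chain: the 4-bromobenzyl group gives a 1.4-fold lower number from compound 2 to compound 4 (0.15 log units; within the scatter). The 3-methoxypropyl chain keeps a real lead, with a 5.2-fold higher number from compound 3 to compound 4 (0.71 log units; beyond the scatter), so the added aromatic ring does not match what that chain gives. Against the free phenol, the change shows an at least 1.5-fold lower number from compound 1 to compound 4 (0.18 log units; that floor lies within the scatter), and this is only a floor since compound 1 stands at a limit: the limit of > 10000 nM in this assay, at which 1 of the 4 values shown sits.

As far as these compounds go, it remains open whether a plain benzyl group would read the same as 4-bromobenzyl. Also open, from the compounds shown here alone, is how a chain ending in an amine, or a longer methoxy-bearing chain, would compare with compound 3.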